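This account rests on a few compounds, and the source may have more. Where it says the series, first, only, none or still open, it means among the compounds named here.

The study looks at a small set of compounds built on the shared core in an ADME assay on THP-1 cells (Homo sapiens) for cytotoxicity; on this read-out higher numbers stand for lower toxicity in this test and lower numbers for higher toxicity in this test. Compound 1, `CC(C)(C)Nc1c(-c2ccccn2)nc2c(OCc3ccccc3)cccn12`, reaches only the limit of the test: in this assay compound 1 gives > 50000 nM, which is a limit and not a measured number. Within the data shown here, compound 2, `COc1ccn2c(Nc3cc(F)cc(F)c3)c(-c3ccccn3)nc2c1`, is the one member with a numeric result, as in this assay compound 2 gives 4300 nM. Compound 3, `c1cncc(-c2nc3ccccn3c2NC2CCCC2)c1`, also ends at the limit: in this assay compound 3 gives > 50000 nM, a limit rather than a number. Among the values shown, compound 3 thus sits at the limit of > 50000 nM in this assay, at which 2 of the 3 values shown sit, and its standing relative to the other members can be read no further than that.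

Compound 4, `c1ccn2c(NC3CCCC3)c(-c3nccs3)nc2c1`, has not yet been measured. It differs from compound 3 by 1,3-thiazol-2-yl in place of pyridin-3-yl on an aromatic carbon. Among the measured compounds shown here, no measured pair in the set shares this swap, so nothing here shows how such a change moves the read-out on its own. The expected step in this assay is an at least 1.1-fold lower number from compound 3 to compound 4 (0.04 log units; that floor lies within the scatter), which is no step beyond the scatter. On that basis compound 4 is estimated to give about 45000 nM in this assay, within a range from 12000 nM to 100000 nM, with a fair chance that the test again reports only its limit.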

Compound 4, half-maximal cytotoxic concentration: > 50000 nM
Compound 4 was reported as a limit; the forecaster's own chance of this, stated with the estimate: 60%; at least 1.1-fold (0.04 log units) between middle value and limit.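

Among these compounds, compound 3 and compound 4 both end at a limit in this assay, so no step between them can be read. Compound 4 joins the other compounds at that limit: the limit of > 50000 nM in this assay, at which 3 of the 4 values shown sit.

The compounds shown leave open whether 1,3-thiazol-2-yl in place of pyridin-3-yl moves the half-maximal cytotoxic concentration at all, and in which direction.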